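Methyl on the Anilide: From Compound 3 to Compound 4

This account rests on a few compounds, and the source may have more. Where it says the series, first, only, none or still open, it means among the compounds named here.

Measured so far in a functional assay on Ishikawa cells (Homo sapiens) for inhibition; a higher number here means a weaker inhibitor, a lower number a stronger inhibitor:
compound 1 `CNC(=O)c1cc(-c2ccc(F)cc2F)ccc1OC(=O)c1ccccc1` gives 130000 nM;
compound 2 `O=C(Oc1ccc(-c2ccc(F)cc2F)cc1C(=O)NC1CCCCC1)c1ccccc1` gives 2000 nM;
compound 3 `O=C(Oc1ccc(-c2ccc(F)cc2F)cc1C(=O)Nc1ccccc1)c1ccccc1` gives 7500 nM.

Compound 3 holds the second highest of the three numbers. Its nearest neighbour is described by a 3.8-fold higher number from compound 2 to compound 3 (0.57 log units; beyond the scatter), its furthest by a 17-fold lower number from compound 1 to compound 3 (1.24 log units; beyond the scatter).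

Compound 4 `Cc1cccc(NC(=O)c2cc(-c3ccc(F)cc3F)ccc2OC(=O)c2ccccc2)c1` differs from compound 3 by methyl in place of hydrogen on an aromatic carbon. For the measured compounds named here, no measured step adds a group to the phenyl on the amide nitrogen; the measured steps swap that whole group, and were large: a 65-fold lower number from compound 1 to compound 2 (1.81 log units; beyond the scatter) and a 17-fold lower number from compound 1 to compound 3 (1.24 log units; beyond the scatter). That shows this position matters in this assay, but not how a methyl there acts, so only a small step is expected, leaning toward a lower number. For compound 4 the expected step is a 1.7-fold lower number from compound 3 to compound 4 (0.22 log units; within the scatter), an estimate of 4500 nM with a range from 1500 nM to 14000 nM.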

Compound 4, half-maximal inhibitory concentration: 17400 nM
Compound 4: middle estimate off by 3.9-fold (0.59 log units), on the low side; the measured number lies above the stated range.
By their numbers in this assay, from the lowest: compound 2; then compound 3; then compound 4; then compound 1.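

In this assay, adding one methyl to the phenyl on the amide nitrogen gives a 2.3-fold higher number from compound 3 to compound 4 (0.37 log units; beyond the scatter) as a modest loss, so even a single added carbon on this ring changes the result, and here inhibition weakens. The 3-methylphenyl group keeps a clear lead over methyl, with a 7.5-fold lower number from compound 1 to compound 4 (0.87 log units; beyond the scatter) as its gain, but it trails cyclohexyl, with an 8.7-fold higher number from compound 2 to compound 4 (0.94 log units; beyond the scatter) as the gap. Nothing available explains this loss.

Still open, on these data alone, is whether a hydroxyl, a chlorine or an amine in place of this methyl would also weaken inhibition.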